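Larger Aromatic Group and Cytotoxicity in Skin Fibroblasts

A few compounds are considered here, and "the series" means these few. Any claim that something is new, unique, unknown or untested is made for them only; others in the source may bear on it.

Compound 1 `CCc1ccc(-c2nc3c(c(C)nn3-c3ccccc3)c(-c3ccccc3O)c2C#N)cc1` is measured in an ADME assay on BJ cells (Homo sapiens) for cytotoxicity, with a stated time of 72 h (on this read-out higher numbers stand for an effect only at larger amounts of compound and lower numbers for an effect already at smaller amounts), where it gives only a limit, > 20000 nM. Going by the values given here, compound 2 `Cc1ccccc1-c1nc2c(c(C)nn2-c2ccccc2)c(-c2ccccc2O)c1C#N` gives the only number in this assay, 21000 nM. The step from compound 1 to compound 2 is a step that the limit leaves unreadable from compound 1 to compound 2, because one value is the limit of > 20000 nM in this assay, at which 1 of the 2 values shown sits. Compound 3 `Cc1nn(-c2ccccc2)c2nc(-c3ccc4ccccc4c3)c(C#N)c(-c3ccccc3O)c12` differs from compound 2 by naphthalen-2-yl in place of 2-methylphenyl on an aromatic carbon. Among the compounds with values here, no measured step gives a readable size for such a change, so the expected step of a 1.1-fold lower number from compound 2 to compound 3 (0.02 log units; within the scatter) in this assay is set near zero, with wide uncertainty. Compound 3 is therefore estimated at 20000 nM, between 7000 nM and 50000 nM.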

Compound 3, half-maximal effective concentration: > 20000 nM
Compound 3: a limit, no number (the forecaster's own chance of this, stated with the estimate: 50%); the middle value lies on the limit itself.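

Neither the step from compound 1 to compound 3 nor the step from compound 2 to compound 3 can be read, because compound 3, like compound 1, gives only a limit: the limit of > 20000 nM in this assay, at which 2 of the 3 values shown sit. The compounds shown leave open whether naphthalen-2-yl, 2-methylphenyl or 4-ethylphenyl at this place makes any difference in this assay.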